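Swapping phenyl for methoxy with only limits in hand

This account rests on a few compounds, and the source may have more. Where it says the series, first, only, none or still open, it means among the compounds named here.

Compound 3 (`CCOC(=O)c1c(-c2cccc(-c3ccccc3)c2)[nH]c2cc(OC(C)C)ccc2c1=O`) carries an isopropyl group on an oxygen and a phenyl group on an aromatic ring. In an ADME assay on Raji cells (Homo sapiens) for cytotoxicity, read by luminescence, with a stated time of 72 h (on this read-out lower numbers stand for an effect already at smaller amounts and higher numbers for an effect only at larger amounts of compound), compound 3 gives > 21500 nM, which is a limit and not a number. Compound 1 (`CCOC(=O)c1c(-c2cccc(-c3ccccc3)c2)[nH]c2cc(OC)ccc2c1=O`) gives > 21500 nM, also a limit. Compound 2 (`CCOC(=O)c1c(-c2cccc(OC)c2)[nH]c2cc(OC)ccc2c1=O`) gives > 21500 nM, again a limit. For the measured compounds named here, the whole series so far therefore stands at the limit of > 21500 nM in this assay, at which 3 of the 3 values shown sit.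

Compound 4 (`CCOC(=O)c1c(-c2cccc(OC)c2)[nH]c2cc(OC(C)C)ccc2c1=O`) has methoxy in place of phenyl on an aromatic carbon. The same swap has been measured once, as a step that the two limits leave unreadable from compound 1 to compound 2. The change on the oxygen appears as a step that the two limits leave unreadable from compound 1 to compound 3, and compound 4 carries both changes. Neither step has a readable size, so no clear shift in either direction is expected in this assay, and another limit is the likeliest result. The expected change is a step that the limit leaves unreadable from compound 3 to compound 4. For compound 4 the estimated value is 25000 nM, with an expected range from 10000 nM to 50000 nM.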

Compound 4, half-maximal effective concentration: > 21500 nM
Compound 4: a limit, no number; the forecaster's own chance of this, stated with the estimate: 85%; the middle value lies beyond the limit too.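

Compound 4 also gives only a limit, so neither its step from compound 3 nor its step from compound 2 can be read. The compounds shown leave open whether either change shifts the read-out in this assay, as every value sits at one limit: the limit of > 21500 nM in this assay, at which 4 of the 4 values shown sit.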